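The source may report more compounds than this note shows. Statements on the series, on what has been measured and on what is new or still open speak of the compounds shown alone.

Among the compounds with values here, in a functional assay on HCT-116 cells (Homo sapiens) for cytotoxicity, read by MTT assay, with a stated time of 72 h (on this read-out lower numbers stand for stronger inhibition and higher numbers for weaker inhibition), compound 2 `O=S(=O)(c1ccc(Br)cc1)c1nc2ccccc2nc1Nc1ccccc1` gives 1110 nM, the only number among the two values shown. Compound 1 `COc1ccc(Nc2nc3ccccc3nc2S(=O)(=O)c2ccc(C)cc2)cc1` reaches only a limit in this assay, > 50000 nM, and the limit of > 50000 nM in this assay, at which 1 of the 2 values shown sits, marks where it sits. Compound 3 `COc1ccc(Nc2nc3ccccc3nc2S(=O)(=O)c2ccc(Br)cc2)cc1` is not yet measured; it differs from compound 2 by methoxy in place of hydrogen on an aromatic carbon. Within the data shown here, no measured step of that change exists, so compound 1 offers only a hint. The author expects a move toward weaker inhibition for the step of a 7.2-fold higher number from compound 2 to compound 3 (0.86 log units; beyond the scatter), and estimates for compound 3 a value of 8000 nM, within 1500 nM to 50000 nM.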

Compound 3, half-maximal inhibitory concentration: 3400 nM
For compound 3 the middle estimate is 2.4-fold (0.37 log units) above the measured one; the range from low to high includes it.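

In this assay the change from phenyl to 4-methoxyphenyl now has a measured size with the bromo held fixed: a 3.1-fold higher number from compound 2 to compound 3 (0.49 log units; beyond the scatter) is a modest loss, and compound 3 still gives a measurable value. With the methoxy held fixed, bromo in place of methyl gives an at least 14-fold lower number from compound 1 to compound 3 (1.16 log units; beyond the scatter) and that step rests on a limit for compound 1, so the methoxy alone does not account for that limit. Nothing measured here gives a reason for either step. From the compounds shown here alone, what an amine, a hydroxyl or a longer chain such as ethoxy would do at this place stays open, as does chloro in place of bromo.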